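Removing a chloro group from compound 2: an expected outcome

A few compounds are considered here, and "the series" means these few. Any claim that something is new, unique, unknown or untested is made for them only; others in the source may bear on it.

Measured compounds:
compound 1 `Nc1nc(Cl)c2ncn(Cc3ccccc3CCl)c2n1` gives > 100000 nM
compound 2 `ClCc1ccccc1Cn1cnc2nc(Cl)nc(Cl)c21` gives "not determined" (no result reported)
compound 3 `ClCc1ccc(Cn2cnc3c(Cl)nc(Cl)nc32)cc1` gives > 100000 nM

In a functional assay on SNB-19 cells (Homo sapiens) for cytotoxicity, read by sulforhodamine B assay, with a stated time of 48 h (on this read-out lower numbers stand for higher toxicity in this test and higher numbers for lower toxicity in this test), compound 1 reaches only a limit, > 100000 nM. Compound 3 likewise reaches only a limit, > 100000 nM. For compound 2 no number is reported in this assay, so it stands nowhere on the numbers shown; what is known is the limit of > 100000 nM in this assay, at which 2 of the 3 values shown sit. Compound 4 `ClCc1ccccc1Cn1cnc2ncnc(Cl)c21` differs from compound 2 by hydrogen in place of chloro on an aromatic carbon. Within the data shown here, no measured step with this change exists, so the size of the step in this assay cannot be read from the data; both measured compounds sit at the limit, and no step beyond the scatter is expected. Compound 4 is therefore expected to give about 100000 nM, within 30000 nM to 300000 nM, most likely again only a limit.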

Compound 4, concentration lethal to 50% of the cells: > 100000 nM
Compound 4: no number, only a limit; the forecaster's own chance of this, stated with the estimate: 75%; the middle value sits exactly at the limit.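

Compound 4 reaches only a limit, > 100000 nM. Among these compounds, compound 2 has no reported number, and no step between compound 2 and compound 4 can be read. The compounds shown leave open whether any change among them shifts the lethal concentration at all: the limit of > 100000 nM in this assay, at which 3 of the 4 values shown sit.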